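The source may hold more compounds than are shown below. What is called first, only, known or untested is meant among the compounds shown, and "the series" means these compounds.

Compound 1 `Cc1cc(O)c(C2=NN(c3ccc(S(N)(=O)=O)cc3)C(c3ccccc3O)C2)cc1Cl`: 64800 nM
Compound 2 `Cc1cc(O)c(C2=NN(c3ccc(S(N)(=O)=O)cc3)C(c3ccccc3Cl)C2)cc1Cl`: a limit, > 100000 nM
Compound 3 `Cc1cc(O)c(C2=NN(c3ccc(S(N)(=O)=O)cc3)C(/C=C/c3ccccc3)C2)cc1Cl`: 52600 nM

In a functional assay on RXF 393 cells (Homo sapiens) for antiproliferative activity, with a stated time of 48 h (on this read-out lower numbers stand for higher toxicity in this test and higher numbers for lower toxicity in this test), compound 1 gives 64800 nM. For compound 2 this assay reports only a limit, > 100000 nM. Compound 3 gives 52600 nM in this assay, the lowest of the two measured numbers. The step of a 1.2-fold lower number from compound 1 to compound 3 (0.09 log units; within the scatter) stays within the scatter, and the step of an at least 1.9-fold lower number from compound 2 to compound 3 (0.27 log units; that floor lies within the scatter), which rests on a limit (the limit of > 100000 nM in this assay, at which 1 of the 3 values shown sits), has a floor that also lies within the scatter. The step of an at least 1.5-fold higher number from compound 1 to compound 2 (0.18 log units; that floor lies within the scatter) likewise has a floor within the scatter.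

Compound 4 `COc1ccc(C2CC(c3cc(Cl)c(C)cc3O)=NN2c2ccc(S(N)(=O)=O)cc2)cc1OC` differs from compound 3 in one place: 3,4-dimethoxyphenyl in place of 2-phenylethenyl on a saturated ring carbon. For the measured compounds named here, two measured steps touch this same saturated ring carbon, from compound 1 to compound 3 and from compound 2 to compound 3, and neither moved this assay beyond the scatter. The three groups tried there so far all gave numbers in the same region or only a limit. The expectation for compound 4 in this assay is therefore a step of no more than the scatter, a 1.1-fold higher number from compound 3 to compound 4 (0.06 log units; within the scatter). Compound 4 is estimated at 60000 nM in this assay, within a range from 25000 nM to 150000 nM.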

Compound 4, concentration lethal to 50% of the cells: 31400 nM
Beside the measured number, compound 4's estimate is 1.9-fold (0.28 log units) above it; measured number inside the range.
By their numbers in this assay, from the lowest: compounds 4, 3 and 1 (each within the scatter of the next, the first and the last beyond it). At a limit, above all of these: compound 2.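

In this assay, for the compounds shown here, this saturated ring carbon now gives its first steps beyond the scatter, both with 3,4-dimethoxyphenyl entering: a 2.1-fold lower number from compound 1 to compound 4 (0.31 log units; beyond the scatter) and an at least 3.1-fold lower number from compound 2 to compound 4 (0.50 log units; beyond the scatter) are larger than the scatter allows, whereas no earlier step at this carbon passed it. The second of these steps is only a floor, as compound 2 is known only as a limit: the limit of > 100000 nM in this assay, at which 1 of the 4 values shown sits. The change from 2-phenylethenyl does not separate the two compounds, for a 1.7-fold lower number from compound 3 to compound 4 (0.22 log units; within the scatter) stays within the scatter, so compound 3 cannot be ordered against compound 4, and the separation holds only between 3,4-dimethoxyphenyl and the two ortho-free comparisons with 2-hydroxyphenyl and 2-chlorophenyl.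

The compounds shown leave open whether both methoxy groups of 3,4-dimethoxyphenyl are needed or whether a single methoxy would give the same number. They also leave open how this carbon would respond to a plain phenyl, a 4-aminophenyl or a phenyl bearing a carboxylic acid.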